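Dog Half-Life Across Four Closely Related Amides

This account rests on a few compounds, and the source may have more. Where it says the series, first, only, none or still open, it means among the compounds named here.

Compound 1 `CC(C)(C)NC(=O)[C@@H]1CN(Cc2cccnc2)CCN1C[C@@H](O)C[C@@H](Cc1cccnc1)C(=O)N[C@H]1c2cccc(Cl)c2C[C@H]1O` gives 0.398 h in an ADME assay on the whole organism for pharmacokinetics, with Canis familiaris (Canis lupus familiaris) as the target; on this read-out lower numbers stand for a shorter-lived compound and higher numbers for a longer-lived compound.
Compound 2 `CC(C)(C)NC(=O)[C@@H]1CN(Cc2cccnc2)CCN1C[C@@H](O)C[C@@H](Cc1cccnc1)C(=O)N[C@H]1c2cccc(F)c2C[C@H]1O` gives 0.478 h in this assay.
Compound 3 `CC(C)(C)NC(=O)[C@@H]1CN(Cc2cccnc2)CCN1C[C@@H](O)C[C@@H](CC1CC1)C(=O)N[C@H]1c2cccc(Cl)c2C[C@H]1O` gives 0.383 h in this assay.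

Two single-point changes link these three. From compound 1 to compound 2 the change is fluoro in place of chloro on an aromatic carbon, and in this assay it gave a 1.2-fold higher number from compound 1 to compound 2 (0.08 log units; within the scatter). From compound 1 to compound 3 the change is cyclopropyl in place of pyridin-3-yl on a saturated chain carbon, two bonds along the chain from a carbonyl carbon, and in this assay it gave a 1.0-fold lower number from compound 1 to compound 3 (0.02 log units; within the scatter). All three numbers thus sit close together.

Compound 4 `CC(C)(C)NC(=O)[C@@H]1CN(Cc2cccnc2)CCN1C[C@@H](O)C[C@@H](CC1CC1)C(=O)N[C@H]1c2cccc(F)c2C[C@H]1O` has not yet been measured. It differs from compound 3 by fluoro in place of chloro on an aromatic carbon, the same change that turned compound 1 into compound 2, and the place of the change is described in identical words for both pairs. The two cores differ by cyclopropyl in place of pyridin-3-yl on a saturated chain carbon, two bonds along the chain from a carbonyl carbon.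

Because the earlier step was a 1.2-fold higher number from compound 1 to compound 2 (0.08 log units; within the scatter), the step from compound 3 to compound 4 in this assay is expected to be similarly small, about a 1.2-fold higher number from compound 3 to compound 4 (0.08 log units; within the scatter). Compound 4 is therefore estimated at 0.46 h, most likely between 0.3 h and 0.72 h.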

Compound 4, half-life: 0.337 h
Estimate against measurement, compound 4: 1.4-fold (0.14 log units) above; low and high end bracket the measured number.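

In this assay, fluoro in place of chloro on the aromatic carbon gives a 1.1-fold lower number from compound 3 to compound 4 (0.06 log units; within the scatter), and this step agrees with the same change on the core of compound 1 as closely as the read-out can tell: the same change on two cores in this assay, a 1.2-fold higher number (0.08 log units; within the scatter) from compound 1 to compound 2 and a 1.1-fold lower number (0.06 log units; within the scatter) from compound 3 to compound 4, 1.4-fold (0.14 log units) apart, within the scatter of two such steps. Cyclopropyl in place of pyridin-3-yl, carried onto the fluoro core, gives a 1.4-fold lower number from compound 2 to compound 4 (0.15 log units; within the scatter), and it too matches its earlier counterpart: the same change on two cores in this assay, a 1.0-fold lower number (0.02 log units; within the scatter) from compound 1 to compound 3 and a 1.4-fold lower number (0.15 log units; within the scatter) from compound 2 to compound 4, 1.4-fold (0.14 log units) apart, within the scatter of two such steps. Within the data shown here, both changes therefore carried from one core to the other with no detectable difference, but every step here lies within the scatter, which means the agreement shows only that neither change shifted the half-life measurably on these cores, not that a larger effect would carry over in the same way.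

The four compounds form a single square of two changes, leaving open whether a methoxy or a nitrile on that aromatic carbon would move the half-life beyond the scatter. The same question stands for a longer chain or a phenyl in place of the cyclopropyl.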